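This account rests on a few compounds, and the source may have more. Where it says the series, first, only, none or still open, it means among the compounds named here.

Compound 1 `CCCOC(=O)CCC(=O)N1CCN(CCCOc2cc3c(Nc4ccc(F)c(Cl)c4)ncnc3cc2OC)CC1` and compound 2 `CCCCCCCCOC(=O)CCC(=O)N1CCN(CCCOc2cc3c(Nc4ccc(F)c(Cl)c4)ncnc3cc2OC)CC1` share one core and differ only in the ester chain. Among the compounds with values here, in a functional assay on A549 cells (Homo sapiens) for cytotoxicity, read by MTT assay, with a stated time of 24 h, tested at 60 uM (on this read-out higher numbers stand for a weaker effect at the one concentration tested and lower numbers for a stronger effect), compound 1 gives 70.4%, the highest of the two numbers so far, while compound 2 gives 26%. Within the data shown here, the single step that has been measured, a number 44.4 percentage points lower from compound 1 to compound 2 (beyond the scatter), is large and well beyond the scatter. Compound 3 `CCCCCCCCCCCOC(=O)CCC(=O)N1CCN(CCCOc2cc3c(Nc4ccc(F)c(Cl)c4)ncnc3cc2OC)CC1` has not yet been measured. It differs from compound 1 by octyl in place of hydrogen on a saturated chain carbon, three bonds along the chain from an oxygen next to a carbonyl group. This is the same kind of change that separates compound 1 from compound 2, only with a longer chain entering, so that one step bears on it directly, and a drop in this assay of at least comparable size is expected, giving a lower number than compound 1 shows. Among the measured compounds shown here, with only one prior step to rest on, the size remains uncertain. Compound 3 is therefore expected to give 15%, within 3% to 40%. That expectation amounts to a step of a number 55.4 percentage points lower from compound 1 to compound 3 (beyond the scatter).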

Compound 3, a percentage reported as activity, at one concentration (the size of the read-out at that concentration, not a potency): 3.9%
Estimate against measurement, compound 3: 11.1 percentage points above; measured number inside the range.
By their numbers in this assay, from the lowest: compound 3; then compound 2; then compound 1.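

In this assay, the ester chain goes on responding once it is longer than in compound 2: octyl in place of hydrogen gives a number 66.5 percentage points lower from compound 1 to compound 3 (beyond the scatter), and the further propyl gives a number 22.1 percentage points lower from compound 2 to compound 3 (beyond the scatter). Across compound 1, compound 2 and compound 3, the number therefore falls with each lengthening of the chain, none of the three goes against this order, and compound 3 has the strongest effect of the three at the one concentration tested. Nothing available explains why the chain has this effect.

Within the data shown here, whether a longer chain than the one in compound 3 would lower the number further remains open. So does whether a branched chain, or a chain ending in an amine or a carboxylic acid, would follow the same order.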